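Bromo in place of iodo on compound 2

A few compounds are considered here, and "the series" means these few. Any claim that something is new, unique, unknown or untested is made for them only; others in the source may bear on it.

Values in an ADME assay on the whole organism (plasma) for pharmacokinetics, with Rattus norvegicus as the target, at a dose of 1 mg/kg by the intravenous route (on this read-out lower numbers stand for lower exposure and higher numbers for higher exposure at the dose given), so far
Compound 1 `O=C(NOC[C@H](O)CO)c1ccc2cnsc2c1Nc1ccc(I)cc1F` gives 1110 ng.h/mL
Compound 2 `O=C(NOCCO)c1ccc2[nH]ncc2c1Nc1ccc(I)cc1F` gives 461 ng.h/mL

Compound 2 stands lowest of these two numbers, and compound 1 lies above it by a gap beyond the usual scatter. Compound 3 `O=C(NOCCO)c1ccc2[nH]ncc2c1Nc1ccc(Br)cc1F` has not yet been measured in this assay and is compared here with compound 2. The change is bromo in place of iodo on an aromatic carbon and the rest of compound 2 stays the same. Among the compounds with values here, no measured pair shows the size of a step for a single change, so the expectation rests on this one exchange alone. The estimated step of a 1.1-fold higher number from compound 2 to compound 3 (0.04 log units; within the scatter) is expected to stay within the scatter, with no clear direction. For compound 3 the expected value is 500 ng.h/mL in an estimated range (from 230 ng.h/mL to 1100 ng.h/mL).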

Compound 3, area under the concentration-time curve: 307 ng.h/mL
Estimate against measurement, compound 3: 1.6-fold (0.21 log units) above; the measured number falls inside the stated range.
By their numbers in this assay, from the lowest: compounds 3 and 2 (each within the scatter of the next); then compound 1.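

In this assay, within the data shown here, the exchange of iodo for bromo on the aromatic carbon para to a large group gives the only comparison here that differs in one place, with a 1.5-fold lower number from compound 2 to compound 3 (0.18 log units; within the scatter) lying within the scatter. The earlier compounds shown here, which differ in more than one place, could not isolate this position, whereas this pair shows that the 2-fluoro-4-iodophenyl and 4-bromo-2-fluorophenyl groups cannot be told apart on this read-out. No supporting measurement bears on the reason for this result.

Going by these compounds, it remains open whether chloro, methyl, a nitrile or an amine at this position would also stay within the scatter of compound 2. On these data alone, it is equally open whether bromo in place of iodo would read the same way on the core and side chain of compound 1.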